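A few compounds are considered here, and "the series" means these few. Any claim that something is new, unique, unknown or untested is made for them only; others in the source may bear on it.

Measured compounds:
compound 1 `CONC(=O)c1sc(-c2ccc(Cl)cc2)nc1C(Br)Br` with 81400 nM
compound 2 `NC(=O)c1sc(-c2ccc(Cl)cc2)nc1C(Br)Br` with 99700 nM
compound 3 `CN(C)C(=O)c1sc(-c2ccc(Cl)cc2)nc1C(Br)Br` with 163000 nM

The three compounds share one core and differ only at the carbonyl carbon. In an ADME assay on BHK15 cells (Mesocricetus auratus) for inhibition, read by XTT assay, with a stated time of 36 h (on this read-out higher numbers stand for weaker inhibition of growth and lower numbers for stronger inhibition of growth), compound 3 gives the highest of the three numbers, yet its nearest neighbour is compound 2 with a step of a 1.6-fold higher number from compound 2 to compound 3 (0.21 log units; within the scatter) and its furthest is compound 1 with a 2.0-fold higher number from compound 1 to compound 3 (0.30 log units; within the scatter), so the three numbers cannot be placed in order. The step from compound 1 to compound 2, a 1.2-fold higher number from compound 1 to compound 2 (0.09 log units; within the scatter), is likewise within the scatter.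

Compound 4 `C=CCNC(=O)c1sc(-c2ccc(Cl)cc2)nc1C(Br)Br` carries allylamino in place of dimethylamino on a carbonyl carbon. The step that bears most closely on it is a 1.6-fold higher number from compound 2 to compound 3 (0.21 log units; within the scatter), which exchanges a group with a donor for dimethylamino, and it was within the scatter. The return to a group with one donor, now allylamino, is therefore expected to move the number in this assay by no more than the scatter, if at all toward the lower side, giving an expected 1.4-fold lower number from compound 3 to compound 4 (0.13 log units; within the scatter). Compound 4 is thus estimated at 120000 nM, with a range from 50000 nM to 300000 nM.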

Compound 4, concentration for 50% growth inhibition: 40800 nM
Compound 4: the middle estimate sits 2.9-fold (0.47 log units) above what was measured, outside the stated range (below it).
By their numbers in this assay, from the lowest: compounds 4, 1, 2 and 3 (each within the scatter of the next, the first and the last beyond it).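

In this assay this carbonyl position now gives steps beyond the scatter, both modest, with allylamino in place of dimethylamino (a 4.0-fold lower number from compound 3 to compound 4 (0.60 log units; beyond the scatter)) and allyl in place of hydrogen on the amide-type nitrogen (a 2.4-fold lower number from compound 2 to compound 4 (0.39 log units; beyond the scatter)), whereas allyl in place of methoxy stays within it (a 2.0-fold lower number from compound 1 to compound 4 (0.30 log units; within the scatter)). Compound 1 and compound 2 also keep the amide hydrogen, yet neither is separated from compound 3 by more than the scatter, so that hydrogen alone does not set compound 4 apart. Nothing in the data shown explains why the allyl amide behaves this way.

As far as these compounds go, it remains open whether the double bond matters or only the chain, which a propyl amide would help to settle. From the compounds shown here alone, whether longer chains or a cyclic amine such as morpholine at this carbonyl carbon would extend the step also remains open.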